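Benzylamino in place of aryloxy on a shared core

A few compounds are considered here, and "the series" means these few. Any claim that something is new, unique, unknown or untested is made for them only; others in the source may bear on it.

Measured compounds in this assay:
compound 1 `Nc1cc(N)c2nc(-c3ccccc3)c(Oc3ccc(Cl)c(Cl)c3)nc2c1`: 14500 nM
compound 2 `CCOC(=O)[C@H](CCC(=O)O)NC(=O)c1ccc(CNc2nc3cc(N)cc(N)c3nc2-c2ccccc2)cc1`: a limit only, < 100000 nM
compound 3 `COc1cc(CNc2nc3cc(N)cc(N)c3nc2-c2ccccc2)cc(OC)c1OC`: a limit only, < 50200 nM

Going by the values given here, in a functional assay on PC-3 cells (Homo sapiens) for inhibition, read by sulforhodamine B assay, with a stated time of 48 h (on this read-out higher numbers stand for weaker inhibition of growth and lower numbers for stronger inhibition of growth), compound 1 gives 14500 nM, the only actual number in the set. For compound 2 the assay reports only a limit, < 100000 nM. For compound 3 it likewise reports only a limit, < 50200 nM. Compound 4 `Nc1cc(N)c2nc(-c3ccccc3)c(NCc3ccc(F)cc3)nc2c1` carries (4-fluorobenzyl)amino in place of 3,4-dichlorophenoxy on an aromatic carbon. Among the compounds with values here, no step between measured compounds is available, and compound 3, which also bears a benzylamino group, gives only a limit and so says nothing about the size of such a change. The step is expected to stay within the scatter, estimated as a 1.2-fold higher number from compound 1 to compound 4 (0.09 log units; within the scatter). Compound 4 is expected at 18000 nM, with a range from 5000 nM to 70000 nM.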

Compound 4, concentration for total growth inhibition: 15500 nM
The estimate for compound 4 lay 1.2-fold (0.06 log units) above the measured number, and the stated range covers the measured number.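

In this assay, placing (4-fluorobenzyl)amino on the aromatic carbon next to the ring nitrogen, in place of 3,4-dichlorophenoxy, gives a 1.1-fold higher number from compound 1 to compound 4 (0.03 log units; within the scatter). Going by these compounds alone, this is the first actual number for a benzylamino group on the shared core, since compound 2 and compound 3 are reported only as limits and their steps cannot be read. No measured property bears on this step. Still open, on these data alone, is what a plain amine or a morpholine at this position would do to the number. Also open, as far as these compounds go, is the effect of a chlorine or a methoxy group in place of the fluorine on the benzyl ring.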